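Fluoro for ethynyl: estimating the clearance of compound 3

The source may report more compounds than this note shows. Statements on the series, on what has been measured and on what is new or still open speak of the compounds shown alone.

Of the compounds shown here, two that share one core have been measured in an ADME assay on microsomes from liver (Canis lupus familiaris) for metabolic stability, read by LC-MS, using NADPH, with a stated time of 10 min, tested at 0.1 uM; on this read-out lower numbers stand for slow clearance and higher numbers for fast clearance. Compound 1 `COc1ccc(F)cc1N1C(=O)CSC1c1cccc(C(=O)NCCCCc2ccccc2)c1` gives 1650 mL.min-1.g-1, and compound 2 `C#Cc1cccc(N2C(=O)CSC2c2cccc(C(=O)NCCCCc3ccccc3)c2)c1` gives 973 mL.min-1.g-1. These two values lie within the scatter of each other, so compound 2 cannot be separated from compound 1 on these numbers.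

Compound 3 `O=C(NCCCCc1ccccc1)c1cccc(C2SCC(=O)N2c2cccc(F)c2)c1` has fluoro in place of ethynyl on an aromatic carbon, meta to a large group, so that 3-ethynylphenyl becomes 3-fluorophenyl: fluoro in place of ethynyl on an aromatic carbon.

Among the compounds with values here, only one measured step bears on this change. Placing 3-ethynylphenyl where 5-fluoro-2-methoxyphenyl stood on an amide-type nitrogen in a ring gave a 1.7-fold lower number from compound 1 to compound 2 (0.23 log units; within the scatter). Within the data shown here, no measured pair compares fluoro with ethynyl directly, so this single step is a limited guide. A shift beyond the scatter in this assay is not expected in either direction. The expected step is a 1.2-fold higher number from compound 2 to compound 3 (0.09 log units; within the scatter). The clearance of compound 3 is estimated at 1200 mL.min-1.g-1, with an expected range from 550 mL.min-1.g-1 to 2600 mL.min-1.g-1.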

Compound 3, intrinsic clearance in microsomes: 837 mL.min-1.g-1
The estimate for compound 3 lay 1.4-fold (0.16 log units) above the measured number, and the stated range covers the measured number.
By their numbers in this assay, from the lowest: compounds 3, 2 and 1 (each within the scatter of the next).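

In this assay, within the data shown here, fluoro in place of ethynyl on an aromatic carbon, meta to a large group, gives a 1.2-fold lower number from compound 2 to compound 3 (0.07 log units; within the scatter) and is the first direct comparison of these two groups, which cannot be told apart at this place on these numbers. Hydrogen in place of methoxy on an aromatic carbon gives a 2.0-fold lower number from compound 1 to compound 3 (0.29 log units; within the scatter) and so also fails to separate the compounds, which means that no single change among compounds 1, 2 and 3 yet moves this read-out beyond the usual scatter. No independent measurement is available to account for any of these numbers.

From the compounds shown here alone, what remains open is whether a different kind of group at this place, such as an amine, a carboxylic acid or a longer chain, would give a number clearly apart from that of compound 3. Going by these compounds, it also remains open whether a change elsewhere on the shared core, for instance on the chain that carries the terminal phenyl, would move this clearance more than the changes on this aromatic ring have done.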